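Loss of the Nitro Group: Expected Effect on Lipophilicity

A few compounds are considered here, and "the series" means these few. Any claim that something is new, unique, unknown or untested is made for them only; others in the source may bear on it.

Measured so far:
compound 1, `C/C(CC(=O)Nc1nnc(-c2ccc(O)cc2)s1)=N\c1ccccn1`: 3.43
compound 2, `C/C(CC(=O)Nc1nnc(/C=C/c2ccccc2)s1)=N\c1ccc([N+](=O)[O-])cn1`: 4.13

In a physicochemical assay for lipophilicity, measured as octanol-water partition (on this read-out higher numbers stand for higher lipophilicity and lower numbers for lower lipophilicity), compound 2 gives 4.13, the higher of the two measured numbers. Compound 1 gives 3.43, and the gap between the two lies beyond the scatter. Compound 3, `C/C(CC(=O)Nc1nnc(/C=C/c2ccccc2)s1)=N\c1ccccn1`, has not yet been measured. It differs from compound 2 in one place: hydrogen in place of nitro on an aromatic carbon. Among the measured compounds shown here, no pair of measured compounds covers this change, so the expectation rests on the change itself. In this assay a small step is expected, upward if anything, and likely within the scatter, so that the expected step from compound 2 to compound 3 is a number 0.22 log units higher from compound 2 to compound 3 (within the scatter). Compound 3 is therefore estimated at 4.35, with a range from 3.95 to 4.75.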

Compound 3, partition coefficient: 4.23
Compound 3: the middle estimate sits 0.12 log units above what was measured; low and high end bracket the measured number.
By their numbers in this assay, from the lowest: compound 1; then compounds 2 and 3 (each within the scatter of the next).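

In this assay, swapping 5-nitropyridin-2-yl for pyridin-2-yl gives a number 0.10 log units higher from compound 2 to compound 3 (within the scatter), so this read-out cannot tell nitro from hydrogen at this position. Changing the other end of the molecule, with 2-phenylethenyl in place of 4-hydroxyphenyl, gives a number 0.80 log units higher from compound 1 to compound 3 (beyond the scatter), a step that can be told from the scatter. Nothing available explains either step. Only nitro and hydrogen are shown at this position, so it remains open whether an amine or a carboxylic acid there would also stay within the scatter.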